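The compounds below may be only part of what the source reports. "The series", "measured", "known", "first", "only" and "open" are said of these compounds alone.

In a functional assay on PANC-1 cells (Homo sapiens) for cytotoxicity, with a stated time of 7 days (a lower number here means a stronger inhibitor, a higher number a weaker inhibitor), compound 3 `COCOC(=O)c1ccccc1SC/C=C(\C)CC/C=C(\C)CCC=C(C)C` gives 12000 nM. Compound 2 `CC(C)=CCC/C(C)=C/CC/C(C)=C/CSc1ccccc1C(N)=O` gives 20000 nM, within the scatter of compound 3, and compound 1 `CC(C)=CCC/C(C)=C/CC/C(C)=C/CSc1ccccc1C(=O)OC(C)C` gives 70000 nM. Compound 4 `CC(C)=CCC/C(C)=C/CC/C(C)=C/CSc1ccccc1C(=O)N(C)C` differs from compound 3 as follows: dimethylamino in place of methoxymethoxy on a carbonyl carbon. Among the measured compounds shown here, the closest precedent is compound 2, with amino on that carbonyl carbon, where a 1.7-fold lower number from compound 2 to compound 3 (0.22 log units; within the scatter) stayed within the scatter. The modest steps of a 3.5-fold lower number from compound 1 to compound 2 (0.54 log units; beyond the scatter) and a 5.8-fold lower number from compound 1 to compound 3 (0.77 log units; beyond the scatter) both start from isopropoxy and bear on it less directly. A small move toward a higher number is therefore expected, not a large one. The expected step is a 1.7-fold higher number from compound 3 to compound 4 (0.22 log units; within the scatter). For compound 4 the estimate is 20000 nM, with an expected range of 8000 nM to 60000 nM.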

Compound 4, half-maximal inhibitory concentration: 22000 nM
For compound 4 the middle estimate is 1.1-fold (0.04 log units) below the measured one, and the stated range covers the measured number.
By their numbers in this assay, from the lowest: compounds 3, 2 and 4 (each within the scatter of the next); then compound 1.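

In this assay, dimethylamino in place of amino on the carbonyl carbon stays within the scatter (a 1.1-fold higher number from compound 2 to compound 4 (0.04 log units; within the scatter)), as does dimethylamino in place of methoxymethoxy (a 1.8-fold higher number from compound 3 to compound 4 (0.26 log units; within the scatter)). Only the isopropoxy compound stands apart (a 3.2-fold lower number from compound 1 to compound 4 (0.50 log units; beyond the scatter)), so the dimethylamino, amino and methoxymethoxy groups cannot be told apart at this position. Nothing available explains these results.

On these data alone, whether a carboxylic acid or a morpholine amide on this carbonyl carbon would separate from these groups remains open.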